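Adding an amino group to compound 2

The source may hold more compounds than are shown below. What is called first, only, known or untested is meant among the compounds shown, and "the series" means these compounds.

Values in an ADME assay on MRC5 cells (Homo sapiens), read by MTT assay, with a stated time of 72 h; on this read-out higher numbers stand for weaker inhibition and lower numbers for stronger inhibition (all three are limits):
- Compound 1 `CSc1ncnc2c1c(-c1ccsc1)cn2[C@@H]1O[C@H](CO)[C@@H](O)[C@H]1O` gives > 100000 nM (a limit)
- Compound 2 `O=c1[nH]cnc2c1c(-c1ccccc1)cn2[C@@H]1O[C@H](CO)[C@@H](O)[C@H]1O` gives > 100000 nM (a limit)
- Compound 3 `O=c1[nH]cnc2c1c(-c1cc3ccccc3o1)cn2[C@@H]1O[C@H](CO)[C@@H](O)[C@H]1O` gives > 100000 nM (a limit)

Compound 2 has no numerical value, only the limit > 100000 nM (a limit), so it cannot be ranked against the other two compounds. Compound 4 `Nc1nc2c(c(-c3ccccc3)cn2[C@@H]2O[C@H](CO)[C@@H](O)[C@H]2O)c(=O)[nH]1` differs from it by one change, amino in place of hydrogen on an aromatic carbon (amino in place of hydrogen on an aromatic carbon, between two ring nitrogen atoms).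

Among the measured compounds shown here, only one measured step starts from compound 2, a step that the two limits leave unreadable from compound 2 to compound 3 (a change of a different group), and it gives no size to carry over. For the measured compounds named here, the wider picture is the limit of > 100000 nM in this assay, at which 3 of the 3 values shown sit (no measured compound gives a number). On that basis, compound 4 is expected to stay with the others, most likely at the same limit, although a measurable value just inside it cannot be excluded. The expected change in this assay is a number no higher from compound 2 to compound 4 (the limit leaves the size open) (no shift beyond the scatter is expected). For compound 4 the estimate is 100000 nM (estimated range 30000 nM to 100000 nM).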

Compound 4, half-maximal inhibitory concentration: > 100000 nM
Compound 4 ended at the assay's limit; the forecaster's own chance of this, stated with the estimate: 80%; the middle value lies on the limit itself.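

Compound 2 and compound 4 are both recorded only as limits, and no step can be read between them. The compounds shown leave open whether amino in place of hydrogen on an aromatic carbon changes the value at all, and how far any compound lies past the limit: the limit of > 100000 nM in this assay, at which 4 of the 4 values shown sit.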